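The source may report more compounds than this note shows. Statements on the series, on what has been measured and on what is new or still open speak of the compounds shown alone.

Measured compounds:
Compound 1, `COc1cc(Nc2nc3ccccc3nc2S(=O)(=O)c2ccccc2)cc(OC)c1`, gives 50 nM in a functional assay on HL-60 cells (Homo sapiens) for cytotoxicity, read by MTT assay, with a stated time of 72 h; on this read-out higher numbers stand for weaker inhibition and lower numbers for stronger inhibition.
Compound 2, `COc1ccc(Nc2nc3ccccc3nc2S(=O)(=O)c2ccc(F)cc2)cc1`, gives 1200 nM in this assay.

Compound 2 stands at the highest of the two numbers in this assay; its nearest neighbour, compound 1, lies well away from it, beyond the usual scatter. The two compounds differ in two places at once, so no single step can be read between them.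

Compound 3, `COc1cc(Nc2nc3ccccc3nc2S(=O)(=O)c2ccc(F)cc2)cc(OC)c1`, has not been measured. It differs from compound 2 in one place: 3,5-dimethoxyphenyl in place of 4-methoxyphenyl on a nitrogen on an aromatic ring. Compound 3 thus carries the same 3,5-dimethoxyphenyl group that compound 1 carries, while keeping the fluorine-bearing sulfonyl ring of compound 2. Since compound 1 with that 3,5-dimethoxyphenyl group gives 50 nM, the change is expected to move the number down by a large amount, beyond the scatter, in this assay.

The expected step is a 15-fold lower number from compound 2 to compound 3 (1.18 log units; beyond the scatter). Compound 3 is estimated at 80 nM in this assay, within a range from 25 nM to 400 nM.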

Compound 3, half-maximal inhibitory concentration: 2360 nM
Estimate against measurement, compound 3: 30-fold (1.47 log units) below; measured number above the stated range.
By their numbers in this assay, from the lowest: compound 1; then compounds 2 and 3 (each within the scatter of the next).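

In this assay, 3,5-dimethoxyphenyl in place of 4-methoxyphenyl on a nitrogen on an aromatic ring gives a 2.0-fold higher number from compound 2 to compound 3 (0.29 log units; within the scatter), so with fluoro on the sulfonyl-bearing ring this change does not separate the two compounds. Fluoro in place of hydrogen on an aromatic carbon, with 3,5-dimethoxyphenyl held fixed, gives a 47-fold higher number from compound 1 to compound 3 (1.67 log units; beyond the scatter); this is the first step that can be read at this place, and it shows that 3,5-dimethoxyphenyl alone does not secure a low number in this pair. No measurement at hand accounts for either step.

The compounds shown leave open how 4-methoxyphenyl behaves with hydrogen in place of fluoro, so whether the size of the fluoro step depends on the group on the nitrogen cannot yet be said. Also open, as far as these compounds go, is whether chloro, methyl or an amine on that same aromatic carbon would follow fluoro or hydrogen in this assay series, and so whether the large step is specific to fluoro or extends to other groups there.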